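Aryl exchange repeated on the smaller ring core

The compounds below may be only part of what the source reports. "The series", "measured", "known", "first", "only" and "open" are said of these compounds alone.

Of the compounds shown here, three sharing one aromatic core have been measured in a functional assay on A-431 cells (Homo sapiens) for antiproliferative activity, read by MTT assay, with a stated time of 72 h; a lower number here means a stronger inhibitor, a higher number a weaker inhibitor. Compound 1 `COc1cc2ncnc(Nc3cccc(I)c3)c2cc1OCCCN1CCNCCNCCNCC1` gives 2540 nM in this assay. Compound 2 `COc1cc2ncnc(Nc3ccc(Cl)cc3Cl)c2cc1OCCCN1CCNCCNCCNCC1` differs from compound 1 in one place, (2,4-dichlorophenyl in place of 3-iodophenyl on a nitrogen on an aromatic ring), and in this assay compound 2 gives 4390 nM; the step is a 1.7-fold higher number from compound 1 to compound 2 (0.24 log units; within the scatter). Compound 3 `COc1cc2ncnc(Nc3cccc(I)c3)c2cc1OCCCN1CCNCCNCC1` keeps the 3-iodophenyl group of compound 1 but carries a different ring at the end of the chain, (a group of 9 heavy atoms (6 carbon, 3 nitrogen; one nine-membered non-aromatic ring with 3 hetero atoms) in place of a group of 12 heavy atoms (8 carbon, 4 nitrogen; one twelve-membered non-aromatic ring with 4 hetero atoms), on a saturated chain carbon, three bonds along the chain from an oxygen on an aromatic ring). In this assay compound 3 gives 2220 nM, and the step is a 1.1-fold lower number from compound 1 to compound 3 (0.06 log units; within the scatter). All three numbers lie within the usual scatter of one another, so no order among them can be claimed.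

Compound 4 `COc1cc2ncnc(Nc3ccc(Cl)cc3Cl)c2cc1OCCCN1CCNCCNCC1` has not yet been measured. It stands to compound 3 as compound 2 stands to compound 1: 2,4-dichlorophenyl in place of 3-iodophenyl on a nitrogen on an aromatic ring. The place of the change is described in the same words for both pairs, so this is the same change, made a second time, now on the core of compound 3.

Among the compounds with values here, the one earlier reading of this change, a 1.7-fold higher number from compound 1 to compound 2 (0.24 log units; within the scatter), was a small shift that stayed within the scatter, and the core difference between compound 1 and compound 3 left the number nearly unchanged. On that basis the step from compound 3 to compound 4 is expected to be a 1.7-fold higher number from compound 3 to compound 4 (0.23 log units; within the scatter). Compound 4 is therefore estimated to give 3800 nM in this assay, with a range from 1800 nM to 8000 nM.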

Compound 4, half-maximal inhibitory concentration: 4080 nM
For compound 4 the middle estimate is 1.1-fold (0.03 log units) below the measured one; the range from low to high includes it.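

In this assay, putting 2,4-dichlorophenyl in place of 3-iodophenyl on the core of compound 3 gives a 1.8-fold higher number from compound 3 to compound 4 (0.26 log units; within the scatter), and this step agrees with the earlier reading of the same change on the core of compound 1: the same change on two cores in this assay, a 1.7-fold higher number (0.24 log units; within the scatter) from compound 1 to compound 2 and a 1.8-fold higher number (0.26 log units; within the scatter) from compound 3 to compound 4, 1.1-fold (0.03 log units) apart, within the scatter of two such steps

The exchange of the rings at the end of the chain, read with 2,4-dichlorophenyl in place, gives a 1.1-fold lower number from compound 2 to compound 4 (0.03 log units; within the scatter), and it agrees with its reading on the 3-iodophenyl compounds: the same change on two cores in this assay, a 1.1-fold lower number (0.06 log units; within the scatter) from compound 1 to compound 3 and a 1.1-fold lower number (0.03 log units; within the scatter) from compound 2 to compound 4, 1.1-fold (0.03 log units) apart, within the scatter of two such steps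

Within the data shown here, the four compounds thus form a closed square in which the aryl change reads alike on both cores, but this agreement rests on a single pair of cores, and every step in it lies within the scatter, so it shows only that neither change produced a clear shift here, not that a clear shift elsewhere would carry over from one core to another, and it sets no order among the compounds.

The compounds shown leave open how a phenyl group bearing a nitrile or a methoxy group on the same nitrogen would read, and whether an open-chain amine such as dimethylamine in place of the ring would leave the number where it stands. They also leave open whether the same agreement between the two cores would hold in any measurement other than this assay.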